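From Methoxymethyl to Formyl on a Shared Core

The source may report more compounds than this note shows. Statements on the series, on what has been measured and on what is new or still open speak of the compounds shown alone.

In a functional assay on MCF7 cells (Homo sapiens) for antiproliferative activity, read by MTT assay, with a stated time of 48 h (on this read-out higher numbers stand for weaker inhibition and lower numbers for stronger inhibition), compound 1 `CC(C)=CCC[C@]1(C)/C=C/[C@@H](OC(=O)C=C(C)C)[C@](C)(O)/C=C/C(=O)/C(CF)=C\C1` gives 240 nM, compound 2 `CC(=O)OC/C1=C/C[C@](C)(CCC=C(C)C)/C=C/[C@@H](OC(=O)C=C(C)C)[C@](C)(O)/C=C/C1=O` gives 4510 nM, and compound 3 `COC/C1=C/C[C@](C)(CCC=C(C)C)/C=C/[C@@H](OC(=O)C=C(C)C)[C@](C)(O)/C=C/C1=O` gives 4130 nM. Compound 3 therefore stands level with compound 2, and both lie well above compound 1, the strongest inhibitor of the three.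

The next compound, compound 4 `CC(C)=CCC[C@]1(C)/C=C/[C@@H](OC(=O)C=C(C)C)[C@](C)(O)/C=C/C(=O)/C(C=O)=C\C1`, differs from compound 3 in one place: formyl in place of methoxymethyl on a double-bonded ring carbon. In short, formyl takes the place of methoxymethyl on a double-bonded ring carbon.

Going by the values given here, three measured steps bear on this change. Acetoxy in place of fluoro is a 19-fold higher number from compound 1 to compound 2 (1.27 log units; beyond the scatter), and methoxy in place of fluoro is a 17-fold higher number from compound 1 to compound 3 (1.24 log units; beyond the scatter). Methyl in place of acetyl is a 1.1-fold lower number from compound 2 to compound 3 (0.04 log units; within the scatter). So this part of the molecule can shift the number strongly, yet no measured step tests a formyl group. A moderate move towards compound 1 seems the fairest guess.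

The expected change is a 2.8-fold lower number from compound 3 to compound 4 (0.44 log units; beyond the scatter), an uncertain estimate. Compound 4 is estimated at 1500 nM, with an expected range of 300 nM to 6000 nM.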

Compound 4, half-maximal inhibitory concentration: 12600 nM
Beside the measured number, compound 4's estimate is 8.4-fold (0.92 log units) below it, and the stated range ends below it.
By their numbers in this assay, from the lowest: compound 1; then compounds 3 and 2 (each within the scatter of the next); then compound 4.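

In this assay formyl on this double-bonded ring carbon gives the weakest inhibition of the four, whether set against methoxymethyl (a 3.1-fold higher number from compound 3 to compound 4 (0.48 log units; beyond the scatter)), acetoxymethyl (a 2.8-fold higher number from compound 2 to compound 4 (0.45 log units; beyond the scatter)) or fluoromethyl (a 53-fold higher number from compound 1 to compound 4 (1.72 log units; beyond the scatter)). The earlier compounds shown here showed only that fluoromethyl stands far from two groups that could not be told apart; now the position also separates those two from formyl, so a change here can weaken inhibition further as well as strengthen it. Nothing measured here accounts for this order of the groups.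

The compounds shown leave open whether the strong result of fluoromethyl is particular to fluorine or would also appear with chloromethyl, hydroxymethyl or aminomethyl. They also leave open how a carboxylic acid or a longer chain would fare on this ring carbon.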